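Swapping a Side Chain on the Ring Nitrogen

The source may report more compounds than this note shows. Statements on the series, on what has been measured and on what is new or still open speak of the compounds shown alone.

Three compounds have been measured in an assay for binding affinity to Corticotropin releasing factor receptor (Rattus norvegicus); on this read-out lower numbers stand for stronger inhibition and higher numbers for weaker inhibition:
Compound 1, `CCCC(C)n1c(CC)nc2c(-c3ccc(Cl)cc3C)nccc21`, gives 9.1 nM.
Compound 2, `CCCC(C)n1c(CC)nc2c(-c3ccc(C(F)(F)F)cc3Cl)nccc21`, gives 3.5 nM.
Compound 3, `CCc1nc2c(-c3ccc(C(F)(F)F)cc3Cl)nccc2n1C(CC)C1CC1`, gives 2.9 nM.

Compound 2 and compound 3 share a core and differ in one place: 1-cyclopropylpropyl in place of 1-methylbutyl on an aromatic nitrogen. The step in this assay was a 1.2-fold lower number from compound 2 to compound 3 (0.08 log units; within the scatter), so the two values cannot be told apart. Compound 1 carries a different core; how the two cores differ is not broken down here. Its number is the highest of the three, and its gaps to compound 2 and to compound 3 lie beyond the scatter.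

Compound 4, `CCc1nc2c(-c3ccc(Cl)cc3C)nccc2n1C(CC)C1CC1`, has not been measured. It differs from compound 1 by 1-cyclopropylpropyl in place of 1-methylbutyl on an aromatic nitrogen, the same change, at the same place, that turned compound 2 into compound 3. Because that earlier step was a 1.2-fold lower number from compound 2 to compound 3 (0.08 log units; within the scatter), compound 4 is expected to sit close to compound 1, with an estimated step of a 1.2-fold lower number from compound 1 to compound 4 (0.08 log units; within the scatter). The estimate for compound 4 in this assay is 7.5 nM, expected between 3.5 nM and 16 nM.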

Compound 4, inhibition constant: 14 nM
The estimate for compound 4 lay 1.9-fold (0.27 log units) below the measured number; the range from low to high includes it.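

In this assay, putting 1-cyclopropylpropyl in place of 1-methylbutyl on the aromatic nitrogen gave a 1.5-fold higher number from compound 1 to compound 4 (0.19 log units; within the scatter), so on this second core the swap again moved the number by no more than the scatter. Set side by side, the two cores cannot be told apart in how they respond to this change: the same change on two cores in this assay, a 1.2-fold lower number (0.08 log units; within the scatter) from compound 2 to compound 3 and a 1.5-fold higher number (0.19 log units; within the scatter) from compound 1 to compound 4, 1.9-fold (0.27 log units) apart, within the scatter of two such steps. This suggests that the swap can be carried between these two cores with little consequence for binding, but it rests on just two pairs of compounds: it shows no real gain or loss from the change, and it does not show that the same would hold on any other core.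

The compounds shown leave open whether a side chain on this nitrogen must consist of carbon only, or whether one holding an ether oxygen or an amine would give similar numbers. Also open, from the compounds shown here alone, is how a longer chain or a cyclobutyl ring in the same place would fare on either core.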